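Amino in Place of Piperazine on a Sulfonamide

This account rests on a few compounds, and the source may have more. Where it says the series, first, only, none or still open, it means among the compounds named here.

Of the compounds shown here, two sharing one core have been measured in an assay on HEK293 cells for binding affinity to 5-hydroxytryptamine receptor 6 (Homo sapiens), read by radioligand binding; on this read-out lower numbers stand for stronger inhibition and higher numbers for weaker inhibition. Compound 1 `O=S(=O)(Nc1cccc(N2CCNCC2)c1)c1ccccc1` gives 62 nM in this assay, the smaller of the two numbers recorded. Compound 2 `O=S(=O)(Nc1ccc(N2CCNCC2)cc1)c1ccccc1` gives 85 nM in this assay, and the gap between compound 1 and compound 2 lies within the scatter of repeated measurements, so the two cannot be told apart on these numbers. Compound 3 `Nc1cccc(NS(=O)(=O)c2ccccc2)c1` has not yet been measured. It differs from compound 1 in one place: amino in place of piperazin-1-yl on an aromatic carbon. Within the data shown here, no measured pair shows what such a change does here, so nothing in the data fixes the size of the step. The expectation is a loss of binding strength, with the step from compound 1 to compound 3 estimated at a 16-fold higher number from compound 1 to compound 3 (1.21 log units; beyond the scatter). For compound 3 the estimated value in this assay is 1000 nM, expected to fall between 200 nM and 6000 nM.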

Compound 3, inhibition constant: 2840 nM
Beside the measured number, compound 3's estimate is 2.8-fold (0.45 log units) below it, within the range that was stated.
By their numbers in this assay, from the lowest: compounds 1 and 2 (each within the scatter of the next); then compound 3.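

In this assay, exchanging the piperazin-1-yl group of compound 1 for a lone amino group on this aromatic carbon gives a large step, a 46-fold higher number from compound 1 to compound 3 (1.66 log units; beyond the scatter). Among these compounds, the earlier compounds showed only that moving the piperazin-1-yl group left the number within the scatter; this result shows that binding strength depends heavily on having that group, or something in it, at this place. Nothing measured here explains why the step is so large.

On these data alone, it remains open whether the whole ring is needed or only part of it, a question that a dimethylamino group, a piperidin-1-yl ring or a 2-aminoethylamino chain on the same carbon could help settle. As far as these compounds go, it is also open whether an amino group in place of the piperazin-1-yl group of compound 2 would cost as much.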